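A few compounds are considered here, and "the series" means these few. Any claim that something is new, unique, unknown or untested is made for them only; others in the source may bear on it.

In a functional assay (trachea) with Cavia porcellus as the target (a lower number here means that less compound is needed, a higher number that more compound is needed for the effect), compound 1 (`C=CCn1c(=O)c2[nH]cnc2n(CCC)c1=O`) gives 1600 nM and compound 2 (`CCCn1cnc2c1c(=O)n(C)c(=O)n2CCC`) gives 5000 nM as the higher of the two numbers. The gap between them lies beyond the usual scatter, so more of compound 2 is needed for the effect. Compound 3 (`CCCn1c(=O)n(C)c(=O)c2c1ncn2CC#N`) has not been measured yet. It differs from compound 2 in one place (cyano in place of ethyl on a saturated chain carbon bound to an aromatic nitrogen), so that propyl becomes cyanomethyl. Among the compounds with values here, no measured pair shows this change, so the expectation is a loose one. In this assay a modest step towards a higher number is expected, a little beyond the scatter. The expected step is a 2.4-fold higher number from compound 2 to compound 3 (0.38 log units; beyond the scatter) on this estimate. For compound 3 the estimated value is 12000 nM with an expected range from 3000 nM to 50000 nM in this measurement.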

Compound 3, half-maximal effective concentration: 35300 nM
The estimate for compound 3 lay 2.9-fold (0.47 log units) below the measured number; the range from low to high includes it.
By their numbers in this assay, from the lowest: compound 1; then compound 2; then compound 3.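

In this assay, replacing propyl with cyanomethyl on a saturated chain carbon bound to an aromatic nitrogen gives a 7.1-fold higher number from compound 2 to compound 3 (0.85 log units; beyond the scatter), so much more compound is needed for the effect. Within the data shown here, this is the first direct sign that the group at this place matters in this assay, since compound 1 and compound 2 differ in more than one place and could not isolate a single change. No measurement here accounts for the size of this step.

This single step cannot separate the effect of adding the nitrile from the effect of losing the end of the propyl chain. Going by these compounds, whether a longer chain such as butyl, or an amine, at this place would stay near compound 2 or move towards compound 3 remains open.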